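Trading an amide for a fluorinated chain on a shared core

The compounds below may be only part of what the source reports. "The series", "measured", "known", "first", "only" and "open" are said of these compounds alone.

Of the compounds shown here, two have been measured in an assay on striatum with sodium-dependent dopamine transporter (Rattus norvegicus) as the target; a lower number here means a stronger inhibitor, a higher number a weaker inhibitor. Compound 1 `CN1CC[C@H](c2ccc(Cl)cc2)C(C(=O)Oc2ccccc2)C1` gives 906 nM. Compound 2 `CN1CC[C@H](c2ccc(Cl)cc2)[C@@H](CC(=O)N(C)C)C1` gives 16 nM, the lower of the two numbers, with the gap to compound 1 well beyond the scatter. Compound 3 `CN1CC[C@H](c2ccc(Cl)cc2)[C@@H](CCCF)C1` differs from compound 2 by 2-fluoroethyl in place of dimethylcarbamoyl on a saturated chain carbon bound to a saturated ring carbon. Among the measured compounds shown here, no measured pair shows this kind of change, so the step from compound 2 to compound 3 in this assay is expected to be modest, most likely toward a slightly higher number, possibly none beyond the scatter: a 1.9-fold higher number from compound 2 to compound 3 (0.27 log units; within the scatter). Compound 3 is therefore estimated at 30 nM, in the range 6 nM to 150 nM.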

Compound 3, inhibition constant: 43 nM
Compound 3: middle estimate off by 1.4-fold (0.16 log units), on the low side, and the stated range covers the measured number.
By their numbers in this assay, from the lowest: compound 2; then compound 3; then compound 1.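

In this assay the change to 2-fluoroethyl gives a 2.7-fold higher number from compound 2 to compound 3 (0.43 log units; beyond the scatter) and so costs some binding strength, but only a modest amount. The amide is therefore helpful but not essential at this position, since compound 3 keeps a value of 43 nM without dimethylcarbamoyl. Nothing available explains the size of this step.

As far as these compounds go, it remains open how a plain propyl chain, without the fluorine, would compare with compound 3. From the compounds shown here alone, it is also open whether an amine or a primary amide here would match compound 2.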